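Chloro substitution on the pendant phenyl ring

The source may hold more compounds than are shown below. What is called first, only, known or untested is meant among the compounds shown, and "the series" means these compounds.

Measured compounds:
compound 1, `C=CC(=O)Nc1nc(-c2ccccc2)cs1`: 18600 nM
compound 2, `C=CC(=O)Nc1nc(-c2ccccc2Cl)cs1`: 12300 nM
compound 3, `C=CC(=O)N(Cc1cc(C)no1)c1nc(-c2ccccc2O)cs1`: reported only as a limit, > 30000 nM

All values come from a functional assay on HCT-116 cells (Homo sapiens) for antiproliferative activity, read by MTT assay, with a stated time of 72 h; a lower number here means a stronger inhibitor, a higher number a weaker inhibitor. The change from compound 1 to compound 2 is chloro in place of hydrogen on an aromatic carbon; the step is a 1.5-fold lower number from compound 1 to compound 2 (0.18 log units; within the scatter). Compound 3 differs from compound 1 in more than one place, and the difference between the two cores is not broken down here. For compound 3 only a limit is recorded, (the limit of > 30000 nM in this assay, at which 1 of the 3 values shown sits).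

Compound 4, `C=CC(=O)N(Cc1cc(C)no1)c1nc(-c2ccc(Cl)cc2O)cs1`, is not yet measured in this assay. Its difference from compound 3 is chloro in place of hydrogen on an aromatic carbon. This is the same kind of change as that between compound 1 and compound 2, but the surroundings differ: there the entering chloro sits ortho to a large group, here meta to a hydroxy group and para to a large group. The step expected here, a number no higher from compound 3 to compound 4 (the limit leaves the size open), rests on the small size of a 1.5-fold lower number from compound 1 to compound 2 (0.18 log units; within the scatter). The starting point, compound 3, stands at the limit > 30000 nM. From that starting point, compound 4 is expected to stay near that limit. Compound 4 is estimated at 30000 nM, within 12000 nM to 80000 nM.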

Compound 4, half-maximal inhibitory concentration: > 30000 nM
Compound 4 gave a limit, no number; the forecaster's own chance of this, stated with the estimate: 70%; the middle value lies on the limit itself.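

In this assay compound 3 and compound 4 are both recorded only as a limit, so no step between them can be read: the limit of > 30000 nM in this assay, at which 2 of the 4 values shown sit.

Left open is what number either compound would carry, and whether going from 2-hydroxyphenyl to 4-chloro-2-hydroxyphenyl changes antiproliferative activity at all.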